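The source may hold more compounds than are shown below. What is called first, only, known or untested is meant among the compounds shown, and "the series" means these compounds.

Compound 1 `COc1cc(-c2nnc3n2NC(c2cccs2)C(C(=O)c2ccc(F)cc2)S3)cc(OC)c1OC` gives 27400 nM in a functional assay on PC-3 cells (Homo sapiens) for cytotoxicity, read by MTT assay, with a stated time of 48 h (on this read-out higher numbers stand for weaker inhibition and lower numbers for stronger inhibition), the lowest number among the three compounds measured, and so the strongest inhibitor of the set. Compound 2 `COc1cc(-c2nnc3n2NC(c2ccco2)C(C(=O)c2ccc(C(F)(F)F)cc2)S3)cc(OC)c1OC` gives 77500 nM, and compound 3 `COc1cc(-c2nnc3n2NC(c2ccco2)C(C(=O)c2ccc(Cl)cc2)S3)cc(OC)c1OC` gives 67800 nM; both differ from compound 1 in two places at once, so their gap to compound 1 cannot be pinned on any single change. Among the compounds with values here, the only single-change step measured is a 1.1-fold lower number from compound 2 to compound 3 (0.06 log units; within the scatter), a swap of one substituent on the aryl ring that sits on the carbonyl carbon.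

Compound 4 `COc1cc(C(=O)C2Sc3nnc(-c4cc(OC)c(OC)c(OC)c4)n3NC2c2cccs2)cc(OC)c1OC` differs from compound 1 by 3,4,5-trimethoxyphenyl in place of 4-fluorophenyl on a carbonyl carbon. This replaces that whole aryl ring rather than one substituent on it, so the measured step bears on it only loosely: it shows that a change on this ring left the number within the scatter. With nothing else to go on, no step beyond the scatter is expected, so compound 4 is estimated at 27000 nM, between 9000 nM and 80000 nM, which would mean an expected step of a 1.0-fold lower number from compound 1 to compound 4 (0.01 log units; within the scatter).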

Compound 4, half-maximal inhibitory concentration: > 100000 nM
Compound 4 gave a limit, no number; the forecaster's own chance of this, stated with the estimate: 10%; middle value at least 3.7-fold (0.56 log units) from the limit.
By their numbers in this assay, from the lowest: compound 1; then compounds 3 and 2 (each within the scatter of the next). At a limit, above all of these: compound 4.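

The earlier step on the aryl ring on the carbonyl carbon swapped only one substituent and stayed within the scatter, whereas replacing the whole ring gives an at least 3.6-fold higher number from compound 1 to compound 4 (0.56 log units; beyond the scatter) in this assay, so this position is not indifferent to change. For compound 4 the reading is a limit and not a number: the limit of > 100000 nM in this assay, at which 1 of the 4 values shown sits. The entering 3,4,5-trimethoxyphenyl has 12 heavy atoms and 3 hydrogen-bond acceptors against 7 and 0 for 4-fluorophenyl, but this one step cannot show which of these differences matters.

Going by these compounds, it remains open whether a single methoxy group on this ring would already raise the number, and whether a ring carrying an amine or a carboxylic acid would sit closer to compound 1 or compound 4. On these data alone, it is also open whether the same swap would have a similar effect in compound 2 or compound 3.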